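The source may report more compounds than this note shows. Statements on the series, on what has been measured and on what is new or still open speak of the compounds shown alone.

In an ADME assay on microsomes from liver (Mus musculus) for metabolic stability, read by LC-MS, with NADPH named in the record, with a stated time of 60 min, tested at 1 uM, in the absence of a further agent (a lower number here means that less of the compound is left, a higher number that more of the compound is left), compound 2 `COc1ccc(-c2c(C)nc3c(N4CC[C@@H](NS(=O)(=O)c5ccc(NC(C)=O)cc5)C4)cc(C)nn23)cc1OC` gives > 95%, which is a limit of the assay and not a number. Compound 1 `COc1ccc(-c2c(C)nc3c(N4CC[C@@H](NS(=O)(=O)c5ccccc5)C4)cc(C)nn23)cc1OC` gives > 95%, also a limit. The two compounds together are summed up as the limit of > 95% in this assay, at which 2 of the 2 values shown sit, and nothing finer. Compound 3 `COc1ccc(-c2c(C)nc3c(N4CC[C@@H](NS(=O)(=O)c5ccc(C(C)=O)cc5)C4)cc(C)nn23)cc1OC` carries acetyl in place of acetamido on an aromatic carbon, and the counted difference from compound 2 reads acetyl in place of acetamido on an aromatic carbon here. For the measured compounds named here, the one measured step that bears on this change is a step that the two limits leave unreadable from compound 1 to compound 2, which puts the same acetamido group onto the ring and has no readable size. Going by the values given here, with no sized step to draw on, no change beyond the scatter is expected in this assay and no direction can be given. The expected step is a number no higher from compound 2 to compound 3 (the limit leaves the size open) and stays within the scatter. Compound 3 is estimated at 95%, with an expected range from 82% to 100% for repeated measurements.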

Compound 3, percent of the compound remaining: > 95%
Compound 3 was reported as a limit; the forecaster's own chance of this, stated with the estimate: 55%; the middle value lies on the limit itself.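

In this assay compound 3 gives > 95%, a limit of the assay, and no step among compound 1, compound 2 and compound 3 can be read: the limit of > 95% in this assay, at which 3 of the 3 values shown sit.
Going by these compounds, whether hydrogen, acetamido and acetyl on this aromatic carbon differ at all in percent of compound remaining stays open.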